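The compounds below may be only part of what the source reports. "The series", "measured", "known", "first", "only" and "open" are said of these compounds alone.

Three compounds have been measured in a functional assay on KB cells (Homo sapiens) for antiproliferative activity, read by MTT assay, with a stated time of 48 h; a higher number here means a weaker inhibitor, a lower number a stronger inhibitor:

Compound 1 `CN(C)CCCn1nc(C2=C(c3cn(C)c4ccccc34)C(=O)NC2=O)c2cccnc21` gives > 100000 nM, a limit of the assay.
Compound 2 `Cn1cc(C2=C(c3n[nH]c4ncccc34)C(=O)N(c3cccc4ccccc34)C2=O)c2ccccc21` gives > 100000 nM, a limit of the assay.
Compound 3 `Cn1cc(C2=C(c3nn(CCCN4CCCCC4)c4ncccc34)C(=O)N(c3ccc(Cl)cc3)C2=O)c2ccccc21` gives > 100000 nM, a limit of the assay.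

Compound 1 therefore stands at the limit rather than at a number, and so does every other value here; all three sit at the limit of > 100000 nM in this assay, at which 3 of the 3 values shown sit. For the measured compounds named here, no pair among them differs in one place only, so no measured step is available.

Compound 4 `Cn1cc(C2=C(c3nn(CCCn4cccc4)c4ncccc34)C(=O)NC2=O)c2ccccc21` is the unmeasured partner of compound 1. It differs by 1H-pyrrol-1-yl in place of dimethylamino on a saturated chain carbon, three bonds along the chain from an aromatic nitrogen. With every measured value at the limit, no change of potency beyond the scatter is expected; the expected step is a step that the limit leaves unreadable from compound 1 to compound 4. Compound 4 is estimated at 150000 nM, within 30000 nM to 600000 nM.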

Compound 4, half-maximal inhibitory concentration: > 100000 nM
Compound 4: only a limit was reported (the forecaster's own chance of this, stated with the estimate: 75%); the middle value does not contradict the limit.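

Compound 1 and compound 4 both stand at a limit of the assay, so no step between them can be read: the limit of > 100000 nM in this assay, at which 4 of the 4 values shown sit.

On these data alone, whether 1H-pyrrol-1-yl in place of dimethylamino changes potency at all in this assay stays open, as does which structures would give a measurable number.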